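The source may report more compounds than this note shows. Statements on the series, on what has been measured and on what is new or still open speak of the compounds shown alone.

Measured compounds in a functional assay on the whole organism (artery, strain albino) with Rattus norvegicus as the target, with a stated time of 360 min, at a dose of 10 mg/kg by the oral route; a lower number here means less inhibition, a higher number more inhibition at the dose given (going by the name of the read-out):
compound 1 `COc1ccc(C2N=C(SCc3ccccc3Cl)NC(C)=C2C(=O)Nc2ccc(F)cc2)cc1OC`: 39.2%
compound 2 `CC1=C(C(=O)Nc2ccc([N+](=O)[O-])cc2)C(c2ccc(Br)cc2)N=C(SCc2ccccc2)N1`: 37.6%
compound 3 `CC1=C(C(=O)Nc2ccc([N+](=O)[O-])cc2)C(c2cccc([N+](=O)[O-])c2)N=C(SCc2ccccc2)N1`: 32.5%

Compound 3 stands lowest of these three numbers, but its gaps to compound 2 and to compound 1 both lie within the scatter, so the three cannot be ordered. Going by the values given here, the one measured step, a number 5.1 percentage points lower from compound 2 to compound 3 (within the scatter), changes the group on a saturated ring carbon and is itself within the scatter.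

Compound 4 `CC1=C(C(=O)Nc2ccc([N+](=O)[O-])cc2)C(c2cccc([N+](=O)[O-])c2)N=C(SCc2ccc(F)cc2)N1` differs from compound 3 in one place: fluoro in place of hydrogen on an aromatic carbon. Among the compounds with values here, no measured step alters this part of the shared core, so nothing bears directly on the change. The step of a number 0.5 percentage points higher from compound 3 to compound 4 (within the scatter) is therefore expected to lie within the scatter. For compound 4 the estimate in this assay is 33%, with a range from 20% to 46%.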

Compound 4, a percentage reported as inhibition, in the whole organism at one dose (the size of the read-out at that dose, not a potency): 36.1%
Compound 4: the middle estimate sits 3.1 percentage points below what was measured, within the range that was stated.
By their numbers in this assay, from the lowest: compounds 3, 4, 2 and 1 (each within the scatter of the next).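

In this assay, going by these compounds alone, the only measured change on the ring of the benzylsulfanyl group, phenyl to 4-fluorophenyl, gives a number 3.6 percentage points higher from compound 3 to compound 4 (within the scatter) and so leaves the reading level. This shows that a fluoro para to a large group is accepted here, with no loss of the effect seen with hydrogen. Nothing available explains this result.

On these data alone, whether larger groups are accepted at this place remains open. An amine or a carboxylic acid on the same ring could show whether this position affects the reading at all.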